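The source may report more compounds than this note shows. Statements on the series, on what has been measured and on what is new or still open speak of the compounds shown alone.

Measured compounds:
Compound 1, `CNC(=O)/C=C1\CCc2c(C)cc(F)cc21`: 15%
Compound 2, `CNC(=O)/C=C1\CCc2c(Cl)cc(Cl)cc21`: 9%
Compound 3, `NC(=O)/C=C1\CCc2c(F)cc(Cl)cc21`: 34%

In a functional assay on the whole organism with Rattus norvegicus as the target, with a stated time of 3 h, at a dose of 20 mg/kg by the oral route (a higher number here means more inhibition at the dose given (going by the name of the read-out), a lower number less inhibition), compound 1 gives 15%, which is the second highest of the three numbers. Compound 2 gives 9%, and the gap between compound 2 and compound 1 lies within the scatter of the measurement. Compound 3 gives 34%, a number that stands beyond the scatter above compound 1.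

The step from compound 1 to compound 4, `Cc1cc(F)cc2c1CC/C2=C\C(=O)NC1CC1`, is cyclopropyl in place of methyl on an amide-type nitrogen. Going by the values given here, no measured pair shows this change, so nothing here tells how it shifts the read-out. The account therefore expects a step of a number 3 percentage points higher from compound 1 to compound 4 (within the scatter) in this assay, no larger than the scatter. Compound 4 is estimated at 18%, with a range from 0% to 45%.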

Compound 4, a percentage reported as inhibition, in the whole organism at one dose (the size of the read-out at that dose, not a potency): 5%
Compound 4: the middle estimate sits 13 percentage points above what was measured; low and high end bracket the measured number.
By their numbers in this assay, from the lowest: compounds 4, 2 and 1 (each within the scatter of the next); then compound 3.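

In this assay, going by these compounds alone, cyclopropyl in place of methyl on an amide-type nitrogen gives a number 10 percentage points lower from compound 1 to compound 4 (within the scatter) and is the first change at this place that can be read directly. On the core of compound 1, the two groups are therefore not told apart beyond the scatter. No measured evidence offers an explanation for this result.

From the compounds shown here alone, a longer chain or a chain carrying an amine or a carboxylic acid on this nitrogen remains open. So does whether the same change reads alike on the cores of compound 2 and compound 3.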